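This account rests on a few compounds, and the source may have more. Where it says the series, first, only, none or still open, it means among the compounds named here.

Measured in a functional assay on HCT-116 cells (Homo sapiens) for inhibition, read by CCK-8 assay, with a stated time of 48 h; a lower number here means a stronger inhibitor, a higher number a weaker inhibitor:
- Compound 1 `COc1ccc(CN(C(=O)CSC(=S)N2CCN(C(C)=O)CC2)c2cc(OC)c(OC)c(OC)c2)cc1`: 1370 nM
- Compound 2 `COc1ccc(CN(C(=O)CSC(=S)N2CCN(C(=O)OC(C)(C)C)CC2)c2cc(OC)c(OC)c(OC)c2)cc1`: 620 nM
- Compound 3 `COc1ccc(CN(C(=O)CSC(=S)N2CCN(C(=O)OC(C)(C)C)CC2)c2ccc(Cl)cc2)cc1`: > 20000 nM

The entry for compound 3 is a limit of the assay, not a number.

In this assay, compound 2 gives 620 nM, the lower of the two actual numbers, and its nearest neighbour is compound 1 at 1370 nM.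

Compound 4 `COc1ccc(CN(C(=O)CSC(=S)N2CCN(C(=O)OC(C)(C)C)CC2)c2cc(OC)c(OC)c(OC)c2)cc1Br` has not yet been measured. It differs from compound 2 by one change, bromo in place of hydrogen on an aromatic carbon, ortho to a methoxy group, turning 4-methoxybenzyl into 3-bromo-4-methoxybenzyl.

Within the data shown here, no measured step touches this group, which compounds 1, 2 and 3 all carry unchanged. The modest step, a 2.2-fold lower number from compound 1 to compound 2 (0.34 log units; beyond the scatter), came with tert-butoxy in place of methyl on a carbonyl carbon. The large step, an at least 32-fold higher number from compound 2 to compound 3 (1.50 log units; beyond the scatter), came with 4-chlorophenyl in place of 3,4,5-trimethoxyphenyl on an amide-type nitrogen. These steps show that numbers in this series can move, but they give no direction for the new bromo.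

The expected change is therefore small, with no clear shift beyond the scatter, and the estimated step is a 1.2-fold lower number from compound 2 to compound 4 (0.09 log units; within the scatter). The estimate starts from compound 2 at 620 nM, and the range stays wide on both sides. For compound 4 the expected value is 500 nM, with an estimated range from 120 nM to 2500 nM.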

Compound 4, half-maximal inhibitory concentration: 9710 nM
Estimate against measurement, compound 4: 19-fold (1.29 log units) below, outside the stated range (above it).
By their numbers in this assay, from the lowest: compound 2; then compound 1; then compound 4. At a limit, above all of these: compound 3.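

The 4-methoxybenzyl group was the same in compounds 1, 2 and 3, so they could not show whether this part of the molecule tolerates any change. Turning it into 3-bromo-4-methoxybenzyl, which adds just 1 heavy atom, brings a 16-fold higher number from compound 2 to compound 4 (1.19 log units; beyond the scatter) in this assay, so this position is sensitive to substitution, at least to bromo. Together with an at least 32-fold higher number from compound 2 to compound 3 (1.50 log units; beyond the scatter), this means that compound 2 loses much of its activity with a change at either of these two groups on the amide nitrogen, although compound 3 stands at a limit of the assay, not at a number: the limit of > 20000 nM in this assay, at which 1 of the 4 values shown sits.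

Bromo is the only new group shown at this place. Fluoro, methyl or hydroxyl there would help to tell whether the loss is specific to bromo or is also seen with other added groups. On these data alone, it also remains open whether bromo would have a similar effect in compound 1, and the values shown do not explain why this single atom makes such a large difference.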